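Amide nitrogen substituent change on the shared core

A few compounds are considered here, and "the series" means these few. Any claim that something is new, unique, unknown or untested is made for them only; others in the source may bear on it.

Measured in an assay for inhibition of serine/threonine-protein kinase PLK2 (Homo sapiens), read by FRET and Z'-LYTE, with a stated time of 1 h; a lower number here means a stronger inhibitor, a higher number a weaker inhibitor:
compound 1 `CCCNS(=O)(=O)c1ccc(Nc2ncc3c(n2)N(C2CCCC2)[C@H](CC)C(=O)N3C)cc1` gives 17.8 nM
compound 2 `CCC1C(=O)N(C)c2cnc(-n3ccc4cc(C(N)=O)ccc43)nc2N1c1ccn(C)n1` gives 384 nM
compound 3 `CC[C@@H]1C(=O)N(C)c2cnc(-n3ccc4cc(C(=O)NC5CCCC5)ccc43)nc2N1C1CCCC1` gives 7.06 nM

Compound 3 stands at the lowest number of the three in this assay; compound 1 is nearest to it, with a gap beyond the scatter, and compound 2 is furthest, well beyond the scatter. Among the compounds with values here, compound 2 and compound 3 share much of the core yet differ in several places, so no single step between them is counted.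

The next compound, compound 4 `CCCNC(=O)c1ccc2c(ccn2-c2ncc3c(n2)N(C2CCCC2)[C@H](CC)C(=O)N3C)c1`, is not yet measured. It differs from compound 3 in one place: propyl in place of cyclopentyl on an amide-type nitrogen. In the terms of that change, cyclopentylcarbamoyl becomes propylcarbamoyl on the amide-type nitrogen. Within the data shown here, no measured pair shows this exact change, so the step is open. A modest move is expected, if any, with a lean toward a somewhat higher number; a step within the scatter is also plausible. For compound 4 the expected step from compound 3 in this assay is a 1.7-fold higher number from compound 3 to compound 4 (0.23 log units; within the scatter). For compound 4 in this assay the estimate is 12 nM, with a range from 4 nM to 35 nM.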

Compound 4, half-maximal inhibitory concentration: 11.4 nM
The estimate for compound 4 lay 1.1-fold (0.02 log units) above the measured number; the measured number falls inside the stated range.
By their numbers in this assay, from the lowest: compounds 3, 4 and 1 (each within the scatter of the next, the first and the last beyond it); then compound 2.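

Within the data shown here, the step of a 1.6-fold higher number from compound 3 to compound 4 (0.21 log units; within the scatter) in this assay is the first reading at this position: with propyl in place of cyclopentyl on an amide-type nitrogen, the number stays within the scatter. For this pair, the five-membered carbon ring is not needed to hold the value, and an open chain with fewer heavy atoms serves as well on the shared core. No data given here speak to why the two groups read alike. From the compounds shown here alone, whether a longer chain, or a chain ending in an amine or a carboxylic acid, would read the same on this nitrogen stays open. Also open, going by these compounds, is whether the same exchange would read alike with other groups elsewhere on the core; this one pair carries the whole finding.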